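The source may hold more compounds than are shown below. What is called first, only, known or untested is meant among the compounds shown, and "the series" means these compounds.

In a physicochemical assay for solubility, in phosphate buffer, at pH 6.5 (a higher number here means a more soluble compound, a lower number a less soluble compound), compound 2 `C=C[C@@H]1C[C@]1(NC(=O)[C@@H]1C[C@@H](Oc2nccc3cc(OC)ccc23)CN1C(=O)[C@@H](NC(=O)N[C@H](COC)CC(C)C)C(C)(C)C)C(=O)NS(=O)(=O)C1CC1` stands at 225 ug/mL and is the lower of the two measured compounds, while compound 1 `C=C[C@@H]1C[C@]1(NC(=O)[C@@H]1C[C@@H](Oc2nccc3cc(OC)ccc23)CN1C(=O)[C@@H](NC(=O)N[C@H](COC)C(C)(C)C)C(C)(C)C)C(=O)NS(=O)(=O)C1CC1` stands at 609 ug/mL in the same test. In compound 3 `C=C[C@@H]1C[C@]1(NC(=O)[C@@H]1C[C@@H](Oc2nccc3cc(OC)ccc23)CN1C(=O)[C@@H](NC(=O)N[C@H](C(=O)OC(C)(C)C)C(C)(C)C)C(C)(C)C)C(=O)NS(=O)(=O)C1CC1`, 2,2-dimethyl-1-(tert-butoxycarbonyl)propyl takes the place of 1-(methoxymethyl)-3-methylbutyl on an amide-type nitrogen 2,2-dimethyl-1-(tert-butoxycarbonyl)propyl in place of 1-(methoxymethyl)-3-methylbutyl on an amide-type nitrogen in the step from compound 2. Within the data shown here, the only measured step is a 2.7-fold lower number from compound 1 to compound 2 (0.43 log units; beyond the scatter) and it changed a different group, so a drop of similar modest size is expected in this assay with wide uncertainty. The expected change is a 1.9-fold lower number from compound 2 to compound 3 (0.27 log units; within the scatter) as an estimate only. Compound 3 is estimated at 120 ug/mL with an expected range from 35 ug/mL to 400 ug/mL for now.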

Compound 3, solubility: 1 ug/mL
Estimate against measurement, compound 3: 120-fold (2.08 log units) above; the whole stated range lies above it.
By their numbers in this assay, from the lowest: compound 3; then compound 2; then compound 1.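

In this assay the group on this amide-type nitrogen proves far more sensitive than the earlier step suggested: 2,2-dimethyl-1-(tert-butoxycarbonyl)propyl gives a 230-fold lower number from compound 2 to compound 3 (2.35 log units; beyond the scatter) as a large step, against the modest 2.7-fold lower number from compound 1 to compound 2 (0.43 log units; beyond the scatter) seen before. With the tert-butyl kept, tert-butoxycarbonyl in place of methoxymethyl on the saturated chain carbon gives a 610-fold lower number from compound 1 to compound 3 (2.78 log units; beyond the scatter) as another large step, so this single exchange is enough for a collapse. No measurement here accounts for the drop. Still open, from the compounds shown here alone, is whether the whole ester or only its tert-butyl part matters, which a carboxylic acid or methyl ester on that carbon would help separate.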